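Fluoro to Trifluoromethyl on Two Cores in Cytotoxicity

The compounds below may be only part of what the source reports. "The series", "measured", "known", "first", "only" and "open" are said of these compounds alone.

Two pairs of compounds share a single structural change. Compound 1 `CC(=O)Nc1ccc(O)c(C(=O)/C=C/c2ccc(F)cc2)c1` carries a fluoro group on its outer ring, and compound 2 `CC(=O)Nc1ccc(O)c(C(=O)/C=C/c2ccc(C(F)(F)F)cc2)c1` carries a trifluoromethyl group at that spot. In an ADME assay on THP-1 cells (Homo sapiens) for cytotoxicity, read by flow cytometry and propidium iodide staining, with a stated time of 72 h (a higher number here means a weaker inhibitor, a lower number a stronger inhibitor), compound 1 gives 68800 nM, while compound 2 gives 15500 nM. The change is trifluoromethyl in place of fluoro on an aromatic carbon, and it produced a 4.4-fold lower number from compound 1 to compound 2 (0.65 log units; beyond the scatter).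

Compound 3 `Nc1ccc2oc(-c3ccc(F)cc3)cc(=O)c2c1` sits on a different core; the difference between the two cores is not broken down here. In this assay compound 3 gives 10000 nM, a value within the scatter of compound 2 and beyond the scatter from compound 1. Compound 4 `Nc1ccc2oc(-c3ccc(C(F)(F)F)cc3)cc(=O)c2c1` has not yet been measured. It differs from compound 3 by trifluoromethyl in place of fluoro on an aromatic carbon, the same change at a place described in identical words.

Resting on the one earlier example, which sits on another core, the step in this assay is expected to be a 2.5-fold lower number from compound 3 to compound 4 (0.40 log units; beyond the scatter), with a wide range allowed since only one precedent exists. Compound 4 is thus expected to give 4000 nM, between 1500 nM and 10000 nM.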

Compound 4, half-maximal inhibitory concentration: 1900 nM
Compound 4: the middle estimate sits 2.1-fold (0.32 log units) above what was measured; the measured number falls inside the stated range.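

In this assay, trifluoromethyl in place of fluoro on the core of compound 3 gave a 5.3-fold lower number from compound 3 to compound 4 (0.72 log units; beyond the scatter), so the change moved the number in the same direction on both cores. The two steps also agree in size, which means that here the earlier step was a fair guide to the later one: the same change on two cores in this assay, a 4.4-fold lower number (0.65 log units; beyond the scatter) from compound 1 to compound 2 and a 5.3-fold lower number (0.72 log units; beyond the scatter) from compound 3 to compound 4, 1.2-fold (0.07 log units) apart, within the scatter of two such steps

This is still one pair on each of two cores, so it shows that the step carried over between these two cores, but not that it would hold on any other core in the series, nor why the number falls.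

The compounds shown leave open what other groups at the same spot would do, such as chloro, methoxy, an amine or a carboxylic acid, and whether any of them would follow the same trend on both cores. They also leave open which part of the difference between the two cores matters in this cell-based read-out, as each core carries only these two groups.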